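Adding a Second Methyl to a Weak Anilide

The source may report more compounds than this note shows. Statements on the series, on what has been measured and on what is new or still open speak of the compounds shown alone.

Measured compounds:
- compound 1, `CC(C)(C)c1ccc(NC(=O)c2ccc(-c3ccccn3)cc2)cc1`, 31 nM
- compound 2, `CC(C)(C)c1ccc(NC(=O)c2ccc(-c3ncccn3)cc2)cc1`, 60 nM
- compound 3, `Cc1ccc(NC(=O)c2ccc(-c3ccccn3)cc2)cc1`, 2300 nM

In a functional assay on Dorsal root ganglion for antagonist activity at transient receptor potential cation channel subfamily V member 1 (Rattus norvegicus) (a higher number here means a weaker inhibitor, a lower number a stronger inhibitor), compound 3 gives the highest of the three numbers, a long way beyond the scatter from both others. The unmeasured compound 4, `Cc1ccc(NC(=O)c2ccc(-c3ccccn3)cc2)cc1C`, is made from compound 3 by methyl in place of hydrogen on an aromatic carbon. Among the measured compounds shown here, no measured step is the same change. Two steps are known: a 1.9-fold higher number from compound 1 to compound 2 (0.29 log units; within the scatter), which was small, and a 74-fold higher number from compound 1 to compound 3 (1.87 log units; beyond the scatter), which was large and concerns the same ring. Compound 4 returns only part of the carbon that was lost between compound 1 and compound 3, in a different arrangement, so the direction of a 74-fold higher number from compound 1 to compound 3 (1.87 log units; beyond the scatter) suggests some recovery, but a much smaller one than the full step. For compound 4 a moderate improvement beyond the scatter is expected in this assay, a 2.6-fold lower number from compound 3 to compound 4 (0.41 log units; beyond the scatter). Compound 4 is estimated at 900 nM, with a likely range from 300 nM to 3000 nM.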

Compound 4, half-maximal inhibitory concentration: 2000 nM
The estimate for compound 4 lay 2.2-fold (0.35 log units) below the measured number; the measured number falls inside the stated range.
By their numbers in this assay, from the lowest: compounds 1 and 2 (each within the scatter of the next); then compounds 4 and 3 (each within the scatter of the next).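

In this assay, a methyl in place of hydrogen on an aromatic carbon, ortho to a methyl group, gives a 1.2-fold lower number from compound 3 to compound 4 (0.06 log units; within the scatter) and so does not set compound 4 apart from compound 3. Set against the large step of a 74-fold higher number from compound 1 to compound 3 (1.87 log units; beyond the scatter) on the same ring, this shows that one extra methyl at this position does not stand in for the tert-butyl of compound 1. Nothing available explains why the number stays within the scatter here.

From the compounds shown here alone, it remains open whether a chlorine atom, a methoxy group or an amine at this same position would move the number beyond the scatter. Also open, going by these compounds, is whether this methyl would give a similar result with the pyrimidin-2-yl group of compound 2 in place of pyridin-2-yl.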